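Swapping hydroxy for chloro on a shared core

A few compounds are considered here, and "the series" means these few. Any claim that something is new, unique, unknown or untested is made for them only; others in the source may bear on it.

Compound 1 `Cc1cc(NC(=O)c2cc([N+](=O)[O-])ccc2Cl)cc(-c2nc3ccccc3s2)c1O` sits at the limit of an ADME assay on HEK293 cells (Homo sapiens) for cytotoxicity, with a stated time of 72 h (on this read-out higher numbers stand for an effect only at larger amounts of compound and lower numbers for an effect already at smaller amounts), giving > 25000 nM. Compound 2 `O=C(Nc1nc(-c2ccc(Cl)cc2)cs1)c1cc([N+](=O)[O-])ccc1Cl` gives 15000 nM in this assay. Compound 3 `O=C(Nc1ccc(O)c(-c2nc3ccccc3s2)c1)c1cc([N+](=O)[O-])ccc1Cl` also sits at the limit, giving > 25000 nM in this assay. Going by the values given here, the only step between neighbouring compounds, a step that the two limits leave unreadable from compound 1 to compound 3, is unreadable, both its ends being limits. Compound 3 thus stands at the limit, where compound 1 stands as well, and the limit of > 25000 nM in this assay, at which 2 of the 3 values shown sit, is all that the numbers offer. Compound 4 `O=C(Nc1ccc(Cl)c(-c2nc3ccccc3s2)c1)c1cc([N+](=O)[O-])ccc1Cl` differs from compound 3 by chloro in place of hydroxy on an aromatic carbon. Among the compounds with values here, no measured step bears on this change. With nothing pointing either way, the expected step is a number no higher from compound 3 to compound 4 (the limit leaves the size open), none beyond the scatter. Compound 4 is therefore estimated at 25000 nM, within 10000 nM to 60000 nM.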

Compound 4, half-maximal effective concentration: > 25000 nM
Compound 4: a limit, no number; the forecaster's own chance of this, stated with the estimate: 55%; the middle value lies on the limit itself.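

No step can be read between compound 3 and compound 4, because both sit at a limit of this assay: the limit of > 25000 nM in this assay, at which 3 of the 4 values shown sit. The compounds shown leave open whether chloro in place of hydroxy changes this read-out at all.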